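This account rests on a few compounds, and the source may have more. Where it says the series, first, only, none or still open, it means among the compounds named here.

Of the compounds shown here, three with a shared core have been measured in a functional assay on HCC1937 cells (Homo sapiens) for antiproliferative activity, read by CCK-8 assay, with a stated time of 72 h; on this read-out lower numbers stand for stronger inhibition and higher numbers for weaker inhibition. Compound 1 `O=C(Nc1cccc(-c2oc3cc(-c4ccc(F)cc4)ccc3c(=O)c2O)c1)c1ccc(F)cc1` gives 14200 nM, compound 2 `O=C(Nc1cccc(-c2oc3cc(-c4ccc(F)cc4)ccc3c(=O)c2O)c1)c1ccc(F)cc1F` gives 6980 nM, and compound 3 `Cc1cccc(C(=O)Nc2cccc(-c3oc4cc(-c5ccc(F)cc5)ccc4c(=O)c3O)c2)c1` gives 8030 nM. Compound 2 has the lowest of the three numbers, but its gap to compound 3 is small: the step of a 1.2-fold higher number from compound 2 to compound 3 (0.06 log units; within the scatter) lies within the scatter, so the two cannot be told apart. Among the compounds with values here, only the step of a 2.0-fold lower number from compound 1 to compound 2 (0.31 log units; beyond the scatter) reaches beyond the scatter.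

Compound 4 `O=C(Nc1cccc(-c2oc3cc(-c4ccc(F)cc4)ccc3c(=O)c2O)c1)c1cccc(F)c1` differs from compound 2 in one place: 3-fluorophenyl in place of 2,4-difluorophenyl on a carbonyl carbon. Within the data shown here, two measured steps bear on this. The swap of the whole aryl group on the carbonyl carbon, a 1.2-fold higher number from compound 2 to compound 3 (0.06 log units; within the scatter), and the related swap a 1.8-fold lower number from compound 1 to compound 3 (0.25 log units; within the scatter), both stayed within the scatter. Among the measured compounds shown here, the only step that moved beyond the scatter, a 2.0-fold lower number from compound 1 to compound 2 (0.31 log units; beyond the scatter), came from adding a fluoro, and compound 4 gives up one fluoro relative to compound 2.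

Compound 4 is therefore expected to land close to compound 2, with at most a small drift toward a higher number, as the step of a 1.4-fold higher number from compound 2 to compound 4 (0.13 log units; within the scatter) expresses. For compound 4 the expected value in this assay is 9500 nM, within a range from 4500 nM to 20000 nM.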

Compound 4, half-maximal inhibitory concentration: 6590 nM
Compound 4: middle estimate off by 1.4-fold (0.16 log units), on the high side, within the range that was stated.
By their numbers in this assay, from the lowest: compounds 4, 2, 3 and 1 (each within the scatter of the next, the first and the last beyond it).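

Compound 4 shows that, at this place on the carbonyl carbon, the 3-fluorophenyl group with its single fluorine cannot be told apart from the 2,4-difluorophenyl group (a 1.1-fold lower number from compound 2 to compound 4 (0.02 log units; within the scatter)), so the second fluorine of compound 2 is not needed to hold the number in this assay. The 3-fluorophenyl group also cannot be told apart from the 3-methylphenyl group (a 1.2-fold lower number from compound 3 to compound 4 (0.09 log units; within the scatter)), whereas changing from the 4-fluorophenyl group to the 3-fluorophenyl group gives a modest step that does reach beyond the scatter (a 2.2-fold lower number from compound 1 to compound 4 (0.33 log units; beyond the scatter)), although compound 3 goes against any clean split, since its step from compound 1 stays within the scatter (a 1.8-fold lower number from compound 1 to compound 3 (0.25 log units; within the scatter)). Nothing shown here accounts for these similarities and differences.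

Going by these compounds, all four compounds carry a phenyl ring with only fluorine or methyl on it at this place, so it remains open whether a phenyl ring bearing a carboxylic acid or a dimethylamino group would move the number further. On these data alone, it is equally open how a saturated ring such as cyclohexyl or morpholine would read in place of the aromatic ring.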